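The source may report more compounds than this note shows. Statements on the series, on what has been measured and on what is new or still open speak of the compounds shown alone.

Measured compounds and their values in a functional assay on the whole organism with Mus musculus as the target, in the maximal electroshock model, with stated times of 30 min and 4 h; a lower number here means that less compound is needed, a higher number that more compound is needed for the effect:
Compound 1 `CCCCCOc1ccc2c(c1)C(=O)NCCO2` gives 56.8 mg/kg.
Compound 2 `CCCCCCCOc1ccc2c(c1)C(=O)NCCO2` gives 19 mg/kg.
Compound 3 `O=C1NCCOc2ccc(OCc3ccccc3)cc21` gives 73.1 mg/kg.

Compound 3 shows the highest number of the three. Its gap to compound 1 is within the scatter, as a 1.3-fold higher number from compound 1 to compound 3 (0.11 log units; within the scatter); its gap to compound 2 is beyond the scatter, as a 3.8-fold higher number from compound 2 to compound 3 (0.59 log units; beyond the scatter). The other measured step, a 3.0-fold lower number from compound 1 to compound 2 (0.48 log units; beyond the scatter), lengthens the chain on the ether oxygen.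

Compound 4 `O=C1NCCOc2ccc(OCc3cccc(F)c3)cc21` differs from compound 3 by fluoro in place of hydrogen on an aromatic carbon of a six-membered aromatic ring of carbon only, meta to a large group; cut one bond further out, phenyl to 3-fluorophenyl. For the measured compounds named here, no measured step touches a substituent on this ring: the two steps beyond the scatter both exchange the whole group on the ether oxygen, and the one step at the same attachment point, from compound 1 to compound 3, is within the scatter. There is thus no measured guide for the size or direction of this change, and the expected step of a 1.2-fold lower number from compound 3 to compound 4 (0.09 log units; within the scatter) is one not beyond the scatter. Compound 4 is estimated at 60 mg/kg, with a range from 28 mg/kg to 130 mg/kg.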

Compound 4, dose for half-maximal effect: 73.1 mg/kg
Compound 4: the middle estimate sits 1.2-fold (0.09 log units) below what was measured; the measured number falls inside the stated range.
By their numbers in this assay, from the lowest: compound 2; then compounds 1, 3 and 4 (each within the scatter of the next).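

In this assay, for the compounds shown here, fluoro in place of hydrogen on an aromatic carbon, meta to a large group, gives no change at the digits printed from compound 3 to compound 4 (within the scatter), the only reading so far of a substituent on this ring. Set against the chains on the ether oxygen, 3-fluorophenyl reads as phenyl does: a 3.8-fold higher number from compound 2 to compound 4 (0.59 log units; beyond the scatter), whereas a 1.3-fold higher number from compound 1 to compound 4 (0.11 log units; within the scatter), so within these four compounds the one gap beyond the scatter still separates compound 2 from the rest. No supporting data bear on this result.

As far as these compounds go, whether trifluoromethyl or an amine in place of the fluoro would shift the number stays open, since a single small group on this ring says little about the position in general. Also open, from the compounds shown here alone, is whether a longer chain on the ether oxygen than that of compound 2 would lower the number further.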